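Ethoxycarbonyl in place of hydroxymethyl: outlook for compound 3

The compounds below may be only part of what the source reports. "The series", "measured", "known", "first", "only" and "open" are said of these compounds alone.

In a physicochemical assay for solubility, read by HPLC, at pH 7.4 (on this read-out higher numbers stand for higher solubility and lower numbers for lower solubility), compound 1 (`CCCCCCCc1[nH]c2ccccc2c(=O)c1CO`) gives 50000 nM as the higher of two numbers, and compound 2 (`CCCCCCCc1[nH]c2ccc([N+](=O)[O-])cc2c(=O)c1CO`) gives 5000 nM as the lower. Compound 3 (`CCCCCCCc1[nH]c2ccccc2c(=O)c1C(=O)OCC`) is not yet measured. It carries ethoxycarbonyl in place of hydroxymethyl on an aromatic carbon of the shared core (ethoxycarbonyl in place of hydroxymethyl on an aromatic carbon). Among the compounds with values here, only one measured step bears on this, and only loosely. That step (a 10-fold lower number from compound 1 to compound 2 (1.00 log units; beyond the scatter)) is nitro in place of hydrogen on an aromatic carbon, a modest change beyond the scatter, so it gives a gauge of size and no direct reading for this exchange. Within the data shown here, no measured step involves hydroxymethyl or ethoxycarbonyl. In this assay a lower number is expected, with an estimated step (a 4.2-fold lower number from compound 1 to compound 3 (0.62 log units; beyond the scatter)) of similar or smaller size. Compound 3 is estimated at 12000 nM as the middle value, with an expected range from 3000 nM to 40000 nM for now.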

Compound 3, solubility: 5000 nM
Compound 3: the middle estimate sits 2.4-fold (0.38 log units) above what was measured; the measured number falls inside the stated range.
By their numbers in this assay, from the lowest: compounds 2 and 3 (each within the scatter of the next); then compound 1.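

In this assay, the carbon that carries hydroxymethyl in compound 1 now has a reading of its own: ethoxycarbonyl in its place gives a 10-fold lower number from compound 1 to compound 3 (1.00 log units; beyond the scatter). Within the data shown here, the earlier step covered only nitro in place of hydrogen elsewhere on the shared core, so this is the first sign that the number also moves with an exchange at this carbon, two atoms from the ring nitrogen. No measured evidence at hand accounts for the size or direction of this step.

A single exchange does not separate the loss of hydroxymethyl from the entry of ethoxycarbonyl. Going by these compounds, a carboxylic acid, a primary amide or a plain methyl group at this carbon would help to divide the step between those two parts, and whether the same step holds with nitro also present remains open.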